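A few compounds are considered here, and "the series" means these few. Any claim that something is new, unique, unknown or untested is made for them only; others in the source may bear on it.

Measured compounds:
compound 1 `O=S(=O)(NCC1CCN(CCCc2c[nH]c3ccc(-n4cnnc4)cc23)CC1)c1ccccc1` — 6.2 nM
compound 2 `C[C@@H](NC1CCN(CCCc2c[nH]c3ccc(-n4cnnc4)cc23)CC1)c1ccccc1` — 0.4 nM

Both were tested in an assay on CHO cells for displacement of a labelled ligand from 5-hydroxytryptamine receptor 1D (Homo sapiens); a higher number here means a weaker inhibitor, a lower number a stronger inhibitor. For the measured compounds named here, compound 2 gives the lowest number of the two; its nearest neighbour is compound 1, and the step of a 16-fold lower number from compound 1 to compound 2 (1.19 log units; beyond the scatter) is the only measured step in this set. It shows that swapping the group on the saturated ring carbon can move the number a great deal.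

Compound 3 `CN(Cc1ccsc1)C1CCN(CCCc2c[nH]c3ccc(-n4cnnc4)cc23)CC1` keeps the shared core of compound 2 and changes only that same position: methyl((thiophen-3-yl)methyl)amino in place of (1-phenylethyl)amino on a saturated ring carbon. Going by the values given here, the one measured step bears on this change only loosely, since it swapped a different pair of groups at the same place. With nothing closer to lean on, a modest loss is expected, as the change a 3.8-fold higher number from compound 2 to compound 3 (0.57 log units; beyond the scatter), and compound 3 is estimated at 1.5 nM, within 0.3 nM to 8 nM.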

Compound 3, half-maximal inhibitory concentration: 1.5 nM
Compound 3: middle estimate and measured number agree at the digits printed, within the range that was stated.
By their numbers in this assay, from the lowest: compound 2; then compound 3; then compound 1.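

In this assay, replacing the group on the saturated ring carbon gives a 3.8-fold higher number from compound 2 to compound 3 (0.57 log units; beyond the scatter), so a group with a five-membered aromatic ring containing 1 hetero atom, no hydrogen-bond donor and no defined stereocentre keeps much of the strength of compound 2. For the compounds shown here, the same group still compares well with the one in compound 1, giving a 4.1-fold lower number from compound 1 to compound 3 (0.62 log units; beyond the scatter), which leaves compound 1 with the highest number of the three. No measurement shown here explains either step.

As far as these compounds go, the step from compound 2 to compound 3 changes the aromatic ring, the hydrogen-bond count and the stereocentre together, and the share of each in the difference stays open. From the compounds shown here alone, how a benzyl(methyl)amino group, which has a six-membered aromatic ring and a methyl on the nitrogen, would compare also remains open.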